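A few compounds are considered here, and "the series" means these few. Any claim that something is new, unique, unknown or untested is made for them only; others in the source may bear on it.

Compound 3 `COc1ccc(Nc2nc3nonc3nc2Nc2ccccc2F)cc1` gives 1600 nM in an assay on mitochondria from L6 cells (Rattus norvegicus) for activation, with a stated time of 90 min (on this read-out lower numbers stand for an effect already at smaller amounts and higher numbers for an effect only at larger amounts of compound), and so stands as the higher of the two numbers, yet within the scatter of compound 2 `Cc1cccc(Nc2nc3nonc3nc2Nc2ccccc2F)c1`, which gives 1500 nM; the pair differs by a 1.1-fold higher number from compound 2 to compound 3 (0.03 log units; within the scatter). Compound 1 `Fc1ccccc1Nc1nc2nonc2nc1NCCC(F)(F)F` gives only a limit in this assay, > 100000 nM. The large steps of an at least 66-fold lower number from compound 1 to compound 2 (1.82 log units; beyond the scatter) and an at least 62-fold lower number from compound 1 to compound 3 (1.79 log units; beyond the scatter) rest on that limit (the limit of > 100000 nM in this assay, at which 1 of the 3 values shown sits). Compound 4 `Fc1ccccc1Nc1nc2nonc2nc1Nc1ccccn1` keeps an aromatic ring on the nitrogen: pyridin-2-yl in place of 4-methoxyphenyl on a nitrogen on an aromatic ring. Going by the values given here, the only measured step of the same kind, one aryl for another, is a 1.1-fold higher number from compound 2 to compound 3 (0.03 log units; within the scatter), within the scatter; no measured step involves a ring with a hetero atom. The step from compound 3 to compound 4 is therefore expected to be small, a 1.6-fold higher number from compound 3 to compound 4 (0.19 log units; within the scatter). Compound 4 is estimated at 2500 nM, between 600 nM and 10000 nM.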

Compound 4, half-maximal effective concentration: 9000 nM
Compound 4: middle estimate off by 3.6-fold (0.56 log units), on the low side, within the range that was stated.
By their numbers in this assay, from the lowest: compounds 2 and 3 (each within the scatter of the next); then compound 4. At a limit, above all of these: compound 1.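

At this position, on a nitrogen on an aromatic ring, exchanging one aryl for another can move the number in this assay beyond the scatter: pyridin-2-yl, with 1 hetero atom in its ring, gives a 5.6-fold higher number from compound 3 to compound 4 (0.75 log units; beyond the scatter) and a 6.0-fold higher number from compound 2 to compound 4 (0.78 log units; beyond the scatter). The two carbon-only rings of compound 2 and compound 3 had stayed within the scatter of each other. The step of an at least 11-fold lower number from compound 1 to compound 4 (1.04 log units; beyond the scatter) still favours the aromatic ring, but compound 1 stands only at a limit: the limit of > 100000 nM in this assay, at which 1 of the 4 values shown sits.

Open, as far as these compounds go, is whether the hetero atom itself accounts for the shift, as a single ring cannot separate this. A pyrimidinyl ring, or a phenyl carrying a carboxylic acid, at this place would test how far the trend extends.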